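A few compounds are considered here, and "the series" means these few. Any claim that something is new, unique, unknown or untested is made for them only; others in the source may bear on it.

Measured in a functional assay on HCT-116 cells (Homo sapiens) for antiproliferative activity, with a stated time of 72 h; on this read-out lower numbers stand for stronger inhibition and higher numbers for weaker inhibition:
- compound 1 `Cc1[nH]c2ccccc2c1C1=CCN(Cc2ccc(OCC(=O)NO)cc2)CC1`: 301 nM
- compound 2 `O=C(COc1ccc(CNC2CC=C(c3c[nH]c4ccc(F)cc34)CC2)c(F)c1)NO`: 261 nM
- compound 3 `Cc1ccc2[nH]cc(C3=CCN(Cc4ccc(OCC(=O)NO)cc4F)CC3)c2c1`: 1450 nM

Compound 2, at 261 nM, sits at the stronger end of this small set. Its number is within the scatter of compound 1, at 301 nM, while compound 3, at 1450 nM, lies higher, beyond the scatter.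

The next compound to be tested is compound 4 `Cc1[nH]c2ccccc2c1C1=CCC(NCc2ccc(OCC(=O)NO)cc2F)CC1`. It differs from compound 2 in one place, with 2-methyl-1H-indol-3-yl in place of 5-fluoro-1H-indol-3-yl on a double-bonded ring carbon.

Going by the values given here, no two measured compounds differ in one place only, so no measured step guides this change directly. Compound 1 also carries 2-methyl-1H-indol-3-yl and gives 301 nM, which suggests that this group is compatible with a number near that of compound 2. Compound 3 shows, however, that higher numbers occur in this set.

The expected change in this assay, a 1.1-fold higher number from compound 2 to compound 4 (0.06 log units; within the scatter), is therefore estimated to stay within the scatter, with no clear direction. For compound 4, the estimated value is 300 nM, with an expected range of 110 nM to 850 nM.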

Compound 4, half-maximal inhibitory concentration: 99 nM
Compound 4: the middle estimate sits 3.0-fold (0.48 log units) above what was measured; measured number below the stated range.
By their numbers in this assay, from the lowest: compound 4; then compounds 2 and 1 (each within the scatter of the next); then compound 3.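

In this assay, going by these compounds alone, placing 2-methyl-1H-indol-3-yl instead of 5-fluoro-1H-indol-3-yl on the double-bonded ring carbon gives a 2.6-fold lower number from compound 2 to compound 4 (0.42 log units; beyond the scatter), the first one-place comparison in this set. It shows that this position responds to a swap between two groups with the same ring types and the same number of heavy atoms, and that the fluorine is not needed to reach a lower number. The data shown offer no measurement that explains this shift.

As far as these compounds go, it remains open whether the methyl group, the loss of the fluorine, or both together account for the step; a plain 1H-indol-3-yl group, carrying neither, would separate the two. Also unresolved is whether a longer chain at the same place, such as 2-ethyl-1H-indol-3-yl, would lower the number further, and whether the same swap holds on the core of compound 1.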